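A few compounds are considered here, and "the series" means these few. Any claim that something is new, unique, unknown or untested is made for them only; others in the source may bear on it.

Measured so far:
Compound 1 `CCCCCn1nc(C(=O)N[C@H]2COc3ccccc3N(C)C2=S)nc1Cc1ccccc1`: in a toxicity assay on HT-29 cells (Homo sapiens) for cytotoxicity (on this read-out higher numbers stand for lower toxicity in this test and lower numbers for higher toxicity in this test), compound 1 gives > 100000 nM, which is a limit of the assay, not a number.
Compound 2 `CN1C(=S)[C@@H](NC(=O)c2nc(Cc3ccccc3)n(CCCCC#N)n2)COc2ccccc21`: in this assay compound 2 gives > 100000 nM, again a limit of the assay.
Compound 3 `CN1C(=S)[C@@H](NC(=O)c2nc(Cc3ccccc3)n(C3CCN(C(=O)OC(C)(C)C)CC3)n2)COc2ccccc21`: in this assay compound 3 gives > 100000 nM, likewise a limit.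

Compound 2 therefore stands at the assay limit, and so do the two other values shown; nothing separates the three on these numbers. Going by the values given here, the single one-place step among the measured compounds, a step that the two limits leave unreadable from compound 1 to compound 2, runs from one limit to another and its size cannot be read.

The next compound is compound 4 `CN1C(=S)[C@@H](NC(=O)c2nc(Cc3ccccc3)n(Cc3ccccc3)n2)COc2ccccc21`. The change from compound 2 is phenyl in place of 3-cyanopropyl on a saturated chain carbon bound to an aromatic nitrogen. Among the compounds with values here, no measured step bears on this change directly. What the series offers is the limit of > 100000 nM in this assay, at which 3 of the 3 values shown sit, and given that every value sits at the limit of > 100000 nM in this assay, at which 3 of the 3 values shown sit, no step beyond the scatter is expected in this assay; the expected step is a step that the limit leaves unreadable from compound 2 to compound 4. Compound 4 is thus estimated at 150000 nM, within 50000 nM to 500000 nM, most probably reported as a limit once more.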

Compound 4, half-maximal cytotoxic concentration: > 100000 nM
Compound 4: no number, only a limit (the forecaster's own chance of this, stated with the estimate: 85%); the middle value does not contradict the limit.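

The steps from compound 1 and from compound 2 to compound 4 cannot be read, since all these values are limits of the assay, not numbers: the limit of > 100000 nM in this assay, at which 4 of the 4 values shown sit.
The compounds shown leave open whether these compounds differ at all in this assay.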